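Aryl group on the ring nitrogen: estimate for compound 4

The compounds below may be only part of what the source reports. "The series", "measured", "known", "first", "only" and "open" are said of these compounds alone.

Measured so far in a functional assay on HepG2 cells (Homo sapiens) for inhibition, read by MTT assay, with a stated time of 72 h; on this read-out higher numbers stand for weaker inhibition and lower numbers for stronger inhibition:

Compound 1 `Cc1ccccc1-n1cc(COc2cccc(NC(=O)Nc3ccc(Cl)c(C(F)(F)F)c3)c2)nn1`: 3440 nM
Compound 2 `Cc1ccc(-n2cc(COc3cccc(NC(=O)Nc4ccc(Cl)c(C(F)(F)F)c4)c3)nn2)cc1`: 5430 nM
Compound 3 `O=C(Nc1cccc(OCc2cn(-c3ccccc3F)nn2)c1)Nc1ccc(Cl)c(C(F)(F)F)c1`: 1520 nM

Compound 2 stands at the highest of the three numbers. Its gap to compound 1 is small: a 1.6-fold higher number from compound 1 to compound 2 (0.20 log units; within the scatter), within the scatter, so the two cannot be ordered. Compound 3 sits clearly lower: a 3.6-fold lower number from compound 2 to compound 3 (0.55 log units; beyond the scatter), and likewise a 2.3-fold lower number from compound 1 to compound 3 (0.35 log units; beyond the scatter). Both of the steps beyond the scatter end at compound 3, which carries a 2-fluorophenyl on the aromatic nitrogen of the five-membered aromatic ring with 3 nitrogen.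

Compound 4 `O=C(Nc1cccc(OCc2cn(-c3ccccc3Cl)nn2)c1)Nc1ccc(Cl)c(C(F)(F)F)c1` is the next member. Relative to compound 2 the change is 2-chlorophenyl in place of 4-methylphenyl on an aromatic nitrogen. Going by the values given here, the step that bears most directly on it is the one from compound 2 to compound 3, where a 2-fluorophenyl entered in place of the same 4-methylphenyl; the step from compound 1 to compound 3 points the same way. Compound 4 brings a 2-chlorophenyl, a related halogen-bearing group, so a step of similar direction is expected, though the size is uncertain and may fall nearer the scatter. For compound 4 the expected step is a 2.7-fold lower number from compound 2 to compound 4 (0.43 log units; beyond the scatter). Compound 4 is therefore estimated at 2000 nM, with a range from 900 nM to 4500 nM in this assay.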

Compound 4, half-maximal inhibitory concentration: 1960 nM
Beside the measured number, compound 4's estimate is 1.0-fold (0.01 log units) above it; the range from low to high includes it.
By their numbers in this assay, from the lowest: compounds 3, 4, 1 and 2 (each within the scatter of the next, the first and the last beyond it).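

In this assay, 2-chlorophenyl in place of 4-methylphenyl on the aromatic nitrogen also gives a step beyond the scatter (a 2.8-fold lower number from compound 2 to compound 4 (0.44 log units; beyond the scatter)), so both halogen-bearing compounds, compound 3 and compound 4, now lie clearly lower than compound 2. Chloro in place of fluoro on the aromatic carbon stays within the scatter (a 1.3-fold higher number from compound 3 to compound 4 (0.11 log units; within the scatter)), so the two halogens cannot be ordered at this position, and chloro in place of methyl also stays within it (a 1.8-fold lower number from compound 1 to compound 4 (0.24 log units; within the scatter)), whereas fluoro in place of methyl lies beyond it (a 2.3-fold lower number from compound 1 to compound 3 (0.35 log units; beyond the scatter)); only the fluoro compound is therefore separated from the 2-methylphenyl compound. No measurement among the data bears on what lies behind these steps.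

With only methyl, fluoro and chloro on the aryl group, the compounds shown leave open whether a 2-bromophenyl, 2-methoxyphenyl or unsubstituted phenyl group would sit with compound 3 and compound 4 or with compound 1. A 4-chlorophenyl or 4-fluorophenyl group would be needed to tell the effect of the halogen from that of its place on the ring, since every halogen shown is in a 2-halophenyl group and the only 4-substituted aryl group carries methyl.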